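This account rests on a few compounds, and the source may have more. Where it says the series, first, only, none or still open, it means among the compounds named here.

Within the data shown here, in a functional assay on Malme-3M cells (Homo sapiens) for antiproliferative activity, read by sulforhodamine B assay, with a stated time of 48 h (a lower number here means a stronger inhibitor, a higher number a weaker inhibitor), compound 2 `Nc1cccc2c(-c3cccc(NC(=O)Nc4cc(C(F)(F)F)cc(C(F)(F)F)c4)c3)ccnc12` gives 1500 nM, the lower of the two numbers measured so far. Compound 1 `Nc1cccc2c(-c3cccc(NC(=O)c4ccc(Cl)c(C(F)(F)F)c4)c3)ccnc12` in this assay gives 4900 nM, a gap that lies beyond the scatter; the two share their core and differ in the linker and in the aryl group it carries. Compound 3 `CC(=O)Nc1cccc2c(-c3cccc(NC(=O)Nc4cc(C(F)(F)F)cc(C(F)(F)F)c4)c3)ccnc12` is compound 2 with acetyl in place of hydrogen on a nitrogen on an aromatic ring. Among the measured compounds shown here, no measured pair shows this change, so the step from compound 2 to compound 3 rests on the structures alone; a modest weakening is expected, a 2.3-fold higher number from compound 2 to compound 3 (0.37 log units; beyond the scatter). Compound 3 in this assay is estimated at 3500 nM, with a range from 1200 nM to 11000 nM.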

Compound 3, half-maximal inhibitory concentration: 18100 nM
Estimate against measurement, compound 3: 5.2-fold (0.71 log units) below, and the stated range ends below it.
By their numbers in this assay, from the lowest: compound 2; then compound 1; then compound 3.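

In this assay, among these compounds, the change from amino to acetamido gives a 12-fold higher number from compound 2 to compound 3 (1.08 log units; beyond the scatter) and is the first measured change at this nitrogen on an aromatic ring. Among the compounds shown here, compounds 1 and 2 share the free amino group, so only this step shows that the position responds strongly to substitution. Nothing at hand explains the loss.

From the compounds shown here alone, whether any group on this nitrogen weakens activity or acetyl does so specifically remains open; a methyl group or a methanesulfonyl group there would help separate these. Going by these compounds, whether the change acts alike on compound 1 is also open.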